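The compounds below may be only part of what the source reports. "The series", "measured", "known", "first", "only" and "open" are said of these compounds alone.

In a functional assay on thoracic aorta (Rattus norvegicus, strain Wistar), with a stated time of 15 min (on this read-out higher numbers stand for an effect only at larger amounts of compound and lower numbers for an effect already at smaller amounts), compound 1 `CC(NC(=O)N(C)S(=O)(=O)c1ccccc1)c1ccccc1OCc1ccccc1` gives 21700 nM. Compound 2 `COc1ccc(Br)cc1C(C)NC(=O)N(C)S(=O)(=O)c1ccccc1` gives 16800 nM in this assay; the difference between the two cores of compound 1 and compound 2 is not broken down here. Compound 3 `CC(NC(=O)N(C)S(=O)(=O)c1ccc(Cl)cc1)c1ccccc1OCc1ccccc1` carries one change relative to compound 1, (chloro in place of hydrogen on an aromatic carbon); in this assay compound 3 gives 38400 nM, so that the step of a 1.8-fold higher number from compound 1 to compound 3 (0.25 log units; within the scatter) was small. Within the data shown here, compound 4 `COc1ccc(Br)cc1C(C)NC(=O)N(C)S(=O)(=O)c1ccc(Cl)cc1` has not been measured; it differs from compound 2 by chloro in place of hydrogen on an aromatic carbon, the same change, at the same kind of place, as the one from compound 1 to compound 3. Because the earlier step of a 1.8-fold higher number from compound 1 to compound 3 (0.25 log units; within the scatter) stayed within the scatter, the step from compound 2 to compound 4 in this assay is expected to be of a similar size, a 1.7-fold higher number from compound 2 to compound 4 (0.22 log units; within the scatter). Compound 4 is therefore expected to give about 28000 nM in this assay, with a plausible range from 12000 nM to 70000 nM.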

Compound 4, half-maximal effective concentration: 19100 nM
Estimate against measurement, compound 4: 1.5-fold (0.17 log units) above; low and high end bracket the measured number.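

In this assay, going from phenyl to 4-chlorophenyl gives a 1.1-fold higher number from compound 2 to compound 4 (0.06 log units; within the scatter), which lies within the usual scatter of repeated measurements. Set beside the earlier step on the other core, the two agree: the same change on two cores in this assay, a 1.8-fold higher number (0.25 log units; within the scatter) from compound 1 to compound 3 and a 1.1-fold higher number (0.06 log units; within the scatter) from compound 2 to compound 4, 1.6-fold (0.19 log units) apart, within the scatter of two such steps. This shows that, on these two cores, swapping hydrogen for chloro leaves the read-out within the scatter each time, so the step carries over as one too small to read; it does not show that the two steps are truly identical, nor that other cores in the series would behave the same way.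

Going by these compounds, what remains open is whether a different group at this place, such as an amine or a carboxylic acid, would shift the number beyond the scatter.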